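A few compounds are considered here, and "the series" means these few. Any claim that something is new, unique, unknown or untested is made for them only; others in the source may bear on it.

Compound 1 `COc1ccc(/C=C2\c3cc(OC)c(OC)c(OC)c3CC[C@@H]2O)cc1C#N`: 5 nM
Compound 2 `COc1ccc(/C=C2\c3cc(OC)c(OC)c(OC)c3CC[C@@H]2O)cc1C`: 2560 nM
Compound 3 `COc1ccc(/C=C2\c3cc(OC)c(OC)c(OC)c3CC[C@H]2O)cc1C#N`: 200 nM

All three compounds were tested in a functional assay on HT-29 cells (Homo sapiens) for inhibition, read by MTT assay; a higher number here means a weaker inhibitor, a lower number a stronger inhibitor. Compound 3, at 200 nM, stands second highest of the three numbers, between the other two. Compound 4 `COc1ccc(/C=C2\c3cc(OC)c(OC)c(OC)c3CC[C@H]2O)cc1[N+](=O)[O-]` keeps the configuration of compound 3 and changes one group: nitro in place of cyano on an aromatic carbon.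

For the measured compounds named here, two measured steps bear on this change. The first, at the same aromatic carbon, is large: a 510-fold higher number from compound 1 to compound 2 (2.71 log units; beyond the scatter). It shows that the group at this carbon can matter greatly in this series, but it replaces cyano with methyl and so sets no size for nitro. The second is also large, a 40-fold higher number from compound 1 to compound 3 (1.60 log units; beyond the scatter), and traces to the fact that compounds 1 and 3 differ only in the configuration as drawn. Compound 4 shares the configuration of compound 3, so compound 3 is the fitting baseline.

Going by the values given here, no measured step places nitro on this carbon, so the range is kept wide. The expected step is small, a 1.5-fold higher number from compound 3 to compound 4 (0.18 log units; within the scatter), and lies within the scatter. For compound 4 the estimated value is 300 nM, with an expected range of 60 nM to 1500 nM.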

Compound 4, half-maximal inhibitory concentration: > 10000 nM
Compound 4 gave a limit, no number (the forecaster's own chance of this, stated with the estimate: 5%); middle value at least 33-fold (1.52 log units) away from the limit.
By their numbers in this assay, from the lowest: compound 1; then compound 3; then compound 2. At a limit, above all of these: compound 4.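

In this assay compound 4 gave > 10000 nM, which is a limit of the assay and not a number. With the configuration held fixed, nitro in place of cyano gives an at least 50-fold higher number from compound 3 to compound 4 (1.69 log units; beyond the scatter), so the group at this aromatic carbon also matters greatly in the configuration of compound 3. The earlier compounds showed a replacement of cyano at this carbon only in the configuration of compound 1, as methyl in place of cyano, with a 510-fold higher number from compound 1 to compound 2 (2.71 log units; beyond the scatter); both replacements shown now give a much higher number.

On these data alone, the true size of the step to compound 4 remains unknown, since only a limit bounds it. The compounds shown also leave open whether an amine or a carboxylic acid at this carbon would keep a low number, and how nitro behaves in the configuration of compound 1.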